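This account rests on a few compounds, and the source may have more. Where it says the series, first, only, none or still open, it means among the compounds named here.

Working notes on the series. In a functional assay on NCI-H460 cells (Homo sapiens) for cytotoxicity, read by MTT assay, with a stated time of 72 h (on this read-out higher numbers stand for weaker inhibition and lower numbers for stronger inhibition), compound 1 `CN(C)CCn1cnnc1-c1cc(Oc2ccc(NC(=O)N/N=C/c3ccc(Cl)cc3Cl)cc2F)ccn1` gives 130 nM and compound 2 `COc1ccc(/C=N/NC(=O)Nc2ccc(Oc3ccnc(-c4nncn4CCN(C)C)c3)c(F)c2)c(OC)c1` gives 1570 nM. Going by the values given here, compound 2 thus holds the higher of the two numbers measured so far, separated from compound 1 by a 12-fold higher number from compound 1 to compound 2 (1.08 log units; beyond the scatter). Compound 3 `CN(C)CCn1cnnc1-c1cc(Oc2ccc(NC(=O)N/N=C/c3ccc(O)c(Br)c3)cc2F)ccn1` is not yet measured; it differs from compound 2 by 3-bromo-4-hydroxyphenyl in place of 2,4-dimethoxyphenyl on a carbon with a double bond to nitrogen. Among the compounds with values here, the single measured step that bears on this position is the one from compound 1 to compound 2, which was large. The change to compound 3 restores a halogen to that ring while bringing in a hydroxyl, so the new group resembles neither measured one closely; a step back toward the lower number is expected, though smaller than the full return, giving an expected step of a 3.5-fold lower number from compound 2 to compound 3 (0.54 log units; beyond the scatter). Compound 3 is therefore estimated at 450 nM in this assay, within a range of 120 nM to 1700 nM.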

Compound 3, half-maximal inhibitory concentration: 430 nM
Beside the measured number, compound 3's estimate is 1.0-fold (0.02 log units) above it, and the stated range covers the measured number.
By their numbers in this assay, from the lowest: compound 1; then compound 3; then compound 2.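

In this assay, the position on a carbon with a double bond to nitrogen proves more graded than a two-point contrast could show: 3-bromo-4-hydroxyphenyl in place of 2,4-dimethoxyphenyl gives a 3.7-fold lower number from compound 2 to compound 3 (0.56 log units; beyond the scatter) as a modest step beyond the scatter. Against 2,4-dichlorophenyl, the same group gives a 3.3-fold higher number from compound 1 to compound 3 (0.52 log units; beyond the scatter) as a second modest step beyond the scatter, so compound 3 lies between the two earlier compounds and does not recover the whole of the large step. Nothing measured here on the compounds themselves accounts for these steps.

Bromine and hydroxyl enter together, so the share of each in the step remains open. A 3-bromophenyl or 4-hydroxyphenyl group at this position would separate them, and a 2,4-dibromophenyl group would test whether the lower number extends beyond chlorine.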